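This account rests on a few compounds, and the source may have more. Where it says the series, first, only, none or still open, it means among the compounds named here.

Values in an ADME assay on NIH3T3 cells (Mus musculus) for cytotoxicity, with a stated time of 72 h; on this read-out higher numbers stand for weaker inhibition and lower numbers for stronger inhibition:
- compound 1 `OC[C@H]1O[C@@H](n2cnc3c(NCc4ccccc4Cl)ncnc32)[C@H](O)[C@@H]1O`: > 166000 nM, a limit
- compound 2 `COc1cccc(CNc2ncnc3c2ncn3[C@@H]2O[C@H](CO)[C@@H](O)[C@H]2O)c1`: > 166000 nM, a limit
- compound 3 `COc1cc(CNc2ncnc3c2ncn3[C@@H]2O[C@H](CO)[C@@H](O)[C@H]2O)cc(OC)c1`: "not determined" (no result reported)

Compound 3 has no number of its own in this assay, so it can only be placed beside the other results, which show (the limit of > 166000 nM in this assay, at which 2 of the 3 values shown sit). Compound 4 `OC[C@H]1O[C@@H](n2cnc3c(NCc4ccc(F)cc4Cl)ncnc32)[C@H](O)[C@@H]1O` follows from compound 3 through the change (2-chloro-4-fluorophenyl in place of 3,5-dimethoxyphenyl on a saturated chain carbon bound to a nitrogen on an aromatic ring). Going by the values given here, no measured step starts from compound 3. Among the compounds with values here, the one step that bears on this change is a step that the two limits leave unreadable from compound 1 to compound 2, which also exchanges the group on a saturated chain carbon bound to a nitrogen on an aromatic ring, but it gives no size to carry over. Compound 1, with 2-chlorophenyl in that place, gives > 166000 nM, which is a limit. No readable step is therefore expected in this assay in either direction, and a further result at the limit is the likeliest outcome. For compound 4 the estimated value is 170000 nM, with an expected range from 80000 nM to 400000 nM.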

Compound 4, half-maximal inhibitory concentration: > 166000 nM
Compound 4: only a limit was reported; the forecaster's own chance of this, stated with the estimate: 80%; the middle value is on the limit's open side.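

In this assay compound 4 gives > 166000 nM, which is a limit. The steps to compound 4 from compound 1 and from compound 2 cannot be read. The compounds shown leave open whether any exchange of this group changes the read-out in this assay.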